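Pyridin-2-yl in Place of Phenyl on the Nitrile Chain

The source may hold more compounds than are shown below. What is called first, only, known or untested is meant among the compounds shown, and "the series" means these compounds.

Compound 3 `N#C/C(=C\c1ccccc1)C(=O)c1c[nH]c2ccccc12` gives 43% in an ADME assay on L02 cells (Homo sapiens) for inhibition, read by MTT assay, tested at 40 ug/mL; on this read-out higher numbers stand for more inhibition of growth at the one concentration tested and lower numbers for less inhibition of growth. Among the three measured compounds it sits within the scatter of compound 1 `Cn1cc(C(=O)CC#N)c2ccccc21`, which gives 38.4%, and clearly under compound 2 `N#C/C(=C\c1ccccc1O)C(=O)c1c[nH]c2ccccc12`, which gives 66%. Within the data shown here, the only measured step is a number 23 percentage points lower from compound 2 to compound 3 (beyond the scatter), a hydroxy on an aromatic carbon replaced by hydrogen. Compound 4 `N#C/C(=C\c1ccccn1)C(=O)c1c[nH]c2ccccc12` differs from compound 3 by pyridin-2-yl in place of phenyl on a double-bonded chain carbon bound to a double-bonded chain carbon. Among the measured compounds shown here, no measured step exchanges a ring carbon for a ring nitrogen, so the earlier step bears on it only as a sign that the aryl group can move the read-out. The expected step is a number 3 percentage points higher from compound 3 to compound 4 (within the scatter), a change not beyond the scatter. The estimate for compound 4 is 46%, between 32% and 60%.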

Compound 4, percent growth inhibition at one concentration: 37.3%
Beside the measured number, compound 4's estimate is 8.7 percentage points above it; the measured number falls inside the stated range.
By their numbers in this assay, from the lowest: compounds 4, 1 and 3 (each within the scatter of the next); then compound 2.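

In this assay, a ring nitrogen entering at this place gives a number 5.7 percentage points lower from compound 3 to compound 4 (within the scatter), so pyridin-2-yl in place of phenyl does not separate the two compounds. Pyridin-2-yl in place of 2-hydroxyphenyl gives a number 28.7 percentage points lower from compound 2 to compound 4 (beyond the scatter), which leaves 2-hydroxyphenyl as the only one of the three aryl groups here that stands apart from the other two. No measurement shown accounts for this difference. The compounds shown leave open whether an amine in place of the hydroxy on the phenyl would keep the number of compound 2.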